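The source may report more compounds than this note shows. Statements on the series, on what has been measured and on what is new or still open speak of the compounds shown alone.

Three compounds have so far been measured in a functional assay on A375P cells (Homo sapiens) for antiproliferative activity, read by MTT assay, with a stated time of 48 h; a lower number here means a stronger inhibitor, a higher number a weaker inhibitor:

Compound 1 `Nc1cccc2c(-c3cccc(NC(=O)c4cc(Cl)cc(C(F)(F)F)c4)c3)ccnc12` gives 18500 nM.
Compound 2 `CC(=O)Nc1cccc2c(-c3cccc(NC(=O)c4cc(Cl)cc(C(F)(F)F)c4)c3)ccnc12` gives 6200 nM.
Compound 3 `Nc1cccc2c(-c3cccc(NC(=O)Nc4cc(C(F)(F)F)cc(C(F)(F)F)c4)c3)ccnc12` gives 1400 nM.

Compound 1 and compound 2 share one core and differ in a single place: acetyl in place of hydrogen on a nitrogen on an aromatic ring. This change gave a 3.0-fold lower number from compound 1 to compound 2 (0.47 log units; beyond the scatter). Compound 3 carries a different core; the difference between the core of compound 1 and the core of compound 3 is not broken down here. Compound 4 `CC(=O)Nc1cccc2c(-c3cccc(NC(=O)Nc4cc(C(F)(F)F)cc(C(F)(F)F)c4)c3)ccnc12` has not been measured. It differs from compound 3 by acetyl in place of hydrogen on a nitrogen on an aromatic ring, the same change as between compound 1 and compound 2, made at the same kind of place. Because the earlier step gave a 3.0-fold lower number from compound 1 to compound 2 (0.47 log units; beyond the scatter), a step of similar size is expected from compound 3 to compound 4 in this assay, about a 2.8-fold lower number from compound 3 to compound 4 (0.45 log units; beyond the scatter). Compound 4 is therefore estimated at 500 nM, expected to lie between 200 nM and 1400 nM.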

Compound 4, half-maximal inhibitory concentration: 4400 nM
The estimate for compound 4 lay 8.8-fold (0.94 log units) below the measured number; the measured number lies above the stated range.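

In this assay, acetyl in place of hydrogen on the aromatic amino nitrogen gave a 3.1-fold higher number from compound 3 to compound 4 (0.50 log units; beyond the scatter), so the change that strengthened compound 2 weakened compound 4. The same change therefore moved the number in opposite directions on the two cores: the same change on two cores in this assay, a 3.0-fold lower number (0.47 log units; beyond the scatter) from compound 1 to compound 2 and a 3.1-fold higher number (0.50 log units; beyond the scatter) from compound 3 to compound 4, 9.4-fold (0.97 log units) apart, beyond the scatter of two such steps. This shows that the effect of this change cannot simply be carried from one core to the other in this series, but it does not show which difference between the cores reverses the step, or why.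

The compounds shown leave open how a longer chain such as propionyl, or a methyl group, would behave on that nitrogen on each core. They also leave open which direction the step would take on any further core.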